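Replacing Phenyl with (Furan-2-yl)methyl in Compound 3

A few compounds are considered here, and "the series" means these few. Any claim that something is new, unique, unknown or untested is made for them only; others in the source may bear on it.

In an ADME assay on L02 cells (Homo sapiens) for inhibition, read by CCK-8 assay, with a stated time of 48 h (a higher number here means a weaker inhibitor of growth, a lower number a stronger inhibitor of growth), compound 1 (`Cc1ccccc1Nc1nc(Nc2cc(Cl)ccn2)ncc1Cl`) gives 41500 nM as its value. Compound 2 (`CN1CCN(c2ccc(Nc3ncc(Cl)c(Nc4ccccc4)n3)nc2)CC1`) gives 7990 nM as the lower of the two numbers, a gap beyond the scatter. Compound 3 (`CN1CCN(c2ccc(Nc3ncc(Cl)c(NCc4ccco4)n3)nc2)CC1`) alters compound 2 in one place ((furan-2-yl)methyl in place of phenyl on a nitrogen on an aromatic ring), with (furan-2-yl)methyl in place of phenyl on a nitrogen on an aromatic ring. Going by the values given here, no measured pair shows this change. A small rise toward weaker inhibition of growth is expected (a 1.6-fold higher number from compound 2 to compound 3 (0.21 log units; within the scatter)), about the size of the scatter. For compound 3 the estimated value is 13000 nM with an expected range from 4500 nM to 38000 nM in this measurement.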

Compound 3, concentration for 50% growth inhibition: 45700 nM
For compound 3 the middle estimate is 3.5-fold (0.55 log units) below the measured one; measured number outside the range, above it.
By their numbers in this assay, from the lowest: compound 2; then compounds 1 and 3 (each within the scatter of the next).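

In this assay, the nitrogen carrying the phenyl of compound 2 proves sensitive to what is attached: (furan-2-yl)methyl in place of phenyl gives a 5.7-fold higher number from compound 2 to compound 3 (0.76 log units; beyond the scatter). This single change therefore weakens growth inhibition by more than the usual scatter. No measurement here accounts for the shift.

The compounds shown do not separate the effect of swapping the ring from that of the extra carbon between ring and nitrogen. A benzyl group or a furan-2-yl group on this nitrogen would tell those two apart.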